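Aryl-swapped thiosemicarbazone: from nitro to chloro

The source may report more compounds than this note shows. Statements on the series, on what has been measured and on what is new or still open speak of the compounds shown alone.

Three thiosemicarbazones built on one shared core have been tested in a functional assay on HT-29 cells (Homo sapiens) for cytotoxicity, read by sulforhodamine B assay; on this read-out lower numbers stand for stronger inhibition of growth and higher numbers for weaker inhibition of growth. Compound 1 `COc1ccc(/C=N\NC(=S)NC(C)(C)CCC[C@](C)(O)[C@@H]2CC=C(C)CC2)cc1` gives 35200 nM, compound 2 `CC1=CC[C@@H]([C@@](C)(O)CCCC(C)(C)NC(=S)N/N=C\c2ccc(O)cc2)CC1` gives 31500 nM, and compound 3 `CC1=CC[C@@H]([C@@](C)(O)CCCC(C)(C)NC(=S)N/N=C\c2ccc([N+](=O)[O-])cc2)CC1` gives 62800 nM, the highest of the three numbers, although each step from it to the other two lies within the scatter. Compound 4 `CC1=CC[C@@H]([C@@](C)(O)CCCC(C)(C)NC(=S)N/N=C\c2ccccc2Cl)CC1` carries 2-chlorophenyl in place of 4-nitrophenyl on a carbon with a double bond to nitrogen. The measured steps that bear on such an exchange of the aryl group are a 1.8-fold higher number from compound 1 to compound 3 (0.25 log units; within the scatter) and a 2.0-fold higher number from compound 2 to compound 3 (0.30 log units; within the scatter), neither of them beyond the scatter. No shift beyond the scatter is therefore expected in this assay, the expected step being a 1.4-fold lower number from compound 3 to compound 4 (0.14 log units; within the scatter). Compound 4 is estimated to give about 45000 nM, within a range from 20000 nM to 110000 nM.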

Compound 4, concentration for total growth inhibition: > 100000 nM
Compound 4 gave a limit, no number; the forecaster's own chance of this, stated with the estimate: 15%; middle value at least 2.2-fold (0.34 log units) away from the limit.
By their numbers in this assay, from the lowest: compounds 2, 1 and 3 (each within the scatter of the next). At a limit, above all of these: compound 4.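

In this assay compound 4 gives only a limit and not a number: the limit of > 100000 nM in this assay, at which 1 of the 4 values shown sits. With 2-chlorophenyl on the carbon with a double bond to nitrogen, the aryl group now produces steps beyond the scatter: an at least 3.1-fold higher number from compound 2 to compound 4 (0.50 log units; beyond the scatter) and an at least 2.8-fold higher number from compound 1 to compound 4 (0.45 log units; beyond the scatter). Against the 4-nitrophenyl group the floor stays within the scatter, an at least 1.5-fold higher number from compound 3 to compound 4 (0.20 log units; that floor lies within the scatter), so the true size of that step remains undecided.

The compounds shown leave open whether the chlorine itself or its place on the ring matters. They also leave open how an unsubstituted phenyl or an amine on the ring would read.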